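The source may hold more compounds than are shown below. What is called first, only, known or untested is meant among the compounds shown, and "the series" means these compounds.

Of the compounds shown here, three have been measured in a functional assay on HTB-54 cells (Homo sapiens) for cytotoxicity, read by MTT assay, with a stated time of 72 h; on this read-out higher numbers stand for weaker inhibition of growth and lower numbers for stronger inhibition of growth. Compound 1, `COc1ccc(CNc2nc([Se]C)nc3ccccc23)cc1`, gives 33000 nM. Compound 2, `CCCCC[Se]c1nc([Se]CCCCC)c2cccnc2n1`, gives 15200 nM. Compound 3, `CCCCC[Se]c1nc([Se]CCCCC)c2ccccc2n1`, gives > 100000 nM.

The value for compound 3 is a limit of the assay and not a number; it sits at the limit of > 100000 nM in this assay, at which 1 of the 3 values shown sits. Compound 3 therefore stands only at the weak end of what has been shown, without a number of its own. Compound 4, `CCCCC[Se]c1nc(NCc2ccccc2)c2ccccc2n1`, differs from compound 3 in one place: a group of 8 heavy atoms (7 carbon, 1 nitrogen; one six-membered aromatic ring of carbon only) in place of a group of 6 heavy atoms (5 carbon, 1 selenium; no ring), on an aromatic carbon. Within the data shown here, no step between measured compounds that differ in one place has been recorded, so the size of such a change is not known from these data. Compound 1, which carries an amino group of a related kind together with a selenium substituent, gives 33000 nM, a number rather than a limit. On that ground this step is expected to run towards stronger inhibition, an at least 2.0-fold lower number from compound 3 to compound 4 (0.30 log units; that floor lies within the scatter). For compound 4 the estimate is 50000 nM, within 15000 nM to 200000 nM.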

Compound 4, concentration for 50% growth inhibition: 37700 nM
Compound 4: middle estimate off by 1.3-fold (0.12 log units), on the high side; the measured number falls inside the stated range.
By their numbers in this assay, from the lowest: compound 2; then compounds 1 and 4 (each within the scatter of the next). At a limit, above all of these: compound 3.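

Among these compounds, at this aromatic carbon of the shared core, benzylamino in place of the selenium-bearing chain gives the first recorded step in this assay, with an at least 2.6-fold lower number from compound 3 to compound 4 (0.42 log units; beyond the scatter). This shows that growth inhibition in these cells responds to what this position carries, and that the change here lies beyond the scatter. The value of compound 3 is a limit and not a number, so only a floor for the step is known: the limit of > 100000 nM in this assay, at which 1 of the 4 values shown sits.

The compounds shown leave open whether the change in compound 4 comes from the benzene ring of benzylamino or from its amino nitrogen, which a simple amine such as methylamino at this carbon could help to separate. They also leave open whether the remaining selenium-bearing chain of compound 4 matters, which a plain hydrogen in its place could test.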